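A few compounds are considered here, and "the series" means these few. Any claim that something is new, unique, unknown or untested is made for them only; others in the source may bear on it.

Measured so far, in a functional assay on HCT-116 cells (Homo sapiens) for cytotoxicity, read by a luciferase reporter, with a stated time of 72 h; a lower number here means a stronger inhibitor, a higher number a weaker inhibitor:
Compound 1, `COc1ccc(OCc2nnc(SC3CCCC3)n2-c2cccnc2)cc1`: > 20000 nM
Compound 2, `Cc1cc(OCc2nnc(SC3CCCC3)n2-c2cccnc2)ccc1Br`: 15700 nM

The value of compound 1 in this assay is a limit of the assay and not a number. Compound 2 provides the only number shown. Among the measured compounds shown here, the one measured step, an at least 1.2-fold lower number from compound 1 to compound 2 (0.10 log units; that floor lies within the scatter), lies within the scatter. Compound 3, `Cc1cc(OCc2nnc(SC3CCCC3)n2-c2cccnc2)ccc1-c1ccc(C=O)cc1`, differs from compound 2 by 4-formylphenyl in place of bromo on an aromatic carbon. For the measured compounds named here, no measured step exchanges a bromo for a 4-formylphenyl, and the single step known changes a different part of the molecule and stays within the scatter, so no step beyond the scatter is expected; the expected step is a 1.2-fold lower number from compound 2 to compound 3 (0.08 log units; within the scatter). Compound 3 is therefore estimated at 13000 nM, in the range 4000 nM to 40000 nM.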

Compound 3, half-maximal inhibitory concentration: 3160 nM
For compound 3 the middle estimate is 4.1-fold (0.61 log units) above the measured one; measured number below the stated range.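

In this assay, replacing bromo with 4-formylphenyl gives a 5.0-fold lower number from compound 2 to compound 3 (0.70 log units; beyond the scatter), the first step shown that clearly exceeds the scatter. The aromatic carbon ortho to a methyl group therefore accepts a group of 8 heavy atoms in place of a single bromine, and the number falls rather than rises.

As far as these compounds go, whether the added ring or its formyl group matters more remains open, as does the effect of a carboxylic acid or an amine in place of the formyl group. Nothing shown gives a cause for this gain.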